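Swapping the Propylamino Group for a Small Nitrogen-Rich Group

The compounds below may be only part of what the source reports. "The series", "measured", "known", "first", "only" and "open" are said of these compounds alone.

This small series shares one core, a biaryl amide in which a pyridine ring carries a substituent on the carbon two atoms from the ring nitrogen. Compound 1 `Cc1cccnc1-c1ccc(C(=O)Nc2ccc(C(F)(F)F)cc2)cc1` carries a methyl there, compound 2 `CC(C)(C)c1ccc(NC(=O)c2ccc(-c3ncccc3C#N)cc2)cc1` a cyano group, and compound 3 `CCCNc1cccnc1-c1ccc(C(=O)Nc2ccc(C(C)(C)C)cc2)cc1` a propylamino group. In a functional assay for antagonist activity at transient receptor potential cation channel subfamily V member 1 (Rattus norvegicus) (on this read-out lower numbers stand for stronger inhibition and higher numbers for weaker inhibition), compound 1 gives 81 nM, compound 2 gives 13 nM, and compound 3 gives 37 nM. Compound 3 thus stands second highest of the three numbers: the change from compound 2 to compound 3 (a 2.8-fold higher number from compound 2 to compound 3 (0.45 log units; beyond the scatter)) weakened inhibition modestly, while compound 1 sits at a still higher number.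

Compound 4 `CC(C)(C)c1ccc(NC(=O)c2ccc(-c3ncccc3C(=N)N)cc2)cc1` keeps everything else from compound 3 and alters only that substituent: a group of 3 heavy atoms (1 carbon, 2 nitrogen; no ring) in place of a group of 4 heavy atoms (3 carbon, 1 nitrogen; no ring), on an aromatic carbon. Among the compounds with values here, only one measured step touches this position, the one from compound 2 to compound 3, and it was modest. The incoming group resembles neither the cyano nor the propylamino group closely, so the direction is uncertain. Compound 4 is therefore expected to land close to compound 3, with a 1.1-fold higher number from compound 3 to compound 4 (0.03 log units; within the scatter), and its value in this assay is estimated at 40 nM, within a range from 12 nM to 130 nM.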

Compound 4, half-maximal inhibitory concentration: > 4000 nM
Compound 4: a limit, no number (the forecaster's own chance of this, stated with the estimate: 5%); at least 100-fold (2.00 log units) between middle value and limit.
By their numbers in this assay, from the lowest: compound 2; then compound 3; then compound 1. At a limit, above all of these: compound 4.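

Compound 4 gives no number, only a limit of the read-out: the limit of > 4000 nM in this assay, at which 1 of the 4 values shown sits. In this assay, within the data shown here, the substituent on this aromatic carbon, two atoms from the ring nitrogen, proves far less forgiving than the earlier compounds could show, with an at least 100-fold higher number from compound 3 to compound 4 (2.03 log units; beyond the scatter) and an at least 300-fold higher number from compound 2 to compound 4 (2.48 log units; beyond the scatter), both much larger than the modest 2.8-fold higher number from compound 2 to compound 3 (0.45 log units; beyond the scatter). Heavy-atom count alone does not order these three compounds: the incoming group falls between the cyano and propylamino groups in count, yet compound 4 lies far above both compound 2 and compound 3.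

The compounds shown leave open which feature of the incoming group goes with the loss, as it differs from the propylamino group in its nitrogen count, its double bond outside aromatic rings and its hydrogen-bond donors all at once. An unsubstituted amine, a carboxylic acid or a longer chain on the same carbon would show whether inhibition returns, and how that depends on the group placed there.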